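Replacing 2-chloro-6-fluorobenzyl with 3-methoxybenzyl in compound 3

This account rests on a few compounds, and the source may have more. Where it says the series, first, only, none or still open, it means among the compounds named here.

In a functional assay on K562 cells (Homo sapiens) for cytotoxicity, read by MTT assay, with a stated time of 48 h (a lower number here means a stronger inhibitor, a higher number a weaker inhibitor), compound 3 (`O=C(CN[C@H]1CCN(S(=O)(=O)Cc2ccccc2)C1)N1CCN(Cc2c(F)cccc2Cl)CC1`) gives 65800 nM as the highest of three numbers, ahead of compound 2 (`O=C(CN[C@H]1CCN(S(=O)(=O)Cc2ccccc2)C1)N1CCN(Cc2c(Cl)cccc2Cl)CC1`) at 28400 nM and compound 1 (`Cc1cccc(CN2CCN(C(=O)CN[C@H]3CCN(S(=O)(=O)Cc4ccccc4)C3)CC2)c1`) at 11300 nM so far. Compound 4 (`COc1cccc(CN2CCN(C(=O)CN[C@H]3CCN(S(=O)(=O)Cc4ccccc4)C3)CC2)c1`) differs from compound 3 by 3-methoxyphenyl in place of 2-chloro-6-fluorophenyl on a saturated chain carbon bound to an amine nitrogen in a ring with 3-methoxyphenyl in place of 2-chloro-6-fluorophenyl. The closest guide is a 5.8-fold higher number from compound 1 to compound 3 (0.77 log units; beyond the scatter) with 3-methylphenyl as the group replaced. Also relevant are a 2.5-fold higher number from compound 1 to compound 2 (0.40 log units; beyond the scatter) and a 2.3-fold higher number from compound 2 to compound 3 (0.36 log units; beyond the scatter) as modest steps. Among the compounds with values here, no 3-methoxyphenyl compound has been measured yet. The expected change, largely retracing the first of these steps, is a 4.1-fold lower number from compound 3 to compound 4 (0.61 log units; beyond the scatter) as a modest drop in this assay overall. For compound 4 the estimated value is 16000 nM with an expected range of 7000 nM to 36000 nM in this series.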

Compound 4, half-maximal inhibitory concentration: 60800 nM
For compound 4 the middle estimate is 3.8-fold (0.58 log units) below the measured one, and the stated range ends below it.
By their numbers in this assay, from the lowest: compound 1; then compound 2; then compounds 4 and 3 (each within the scatter of the next).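

Working from this assay the two halogens on the benzyl group can be lost without a shift, since 3-methoxyphenyl in place of 2-chloro-6-fluorophenyl gives (a 1.1-fold lower number from compound 3 to compound 4 (0.03 log units; within the scatter)), while replacing 2,6-dichlorophenyl gives (a 2.1-fold higher number from compound 2 to compound 4 (0.33 log units; beyond the scatter)). Losing the halogens therefore does not by itself recover the level of compound 1: methoxy in place of methyl on an aromatic carbon gives (a 5.4-fold higher number from compound 1 to compound 4 (0.73 log units; beyond the scatter)), a single-group change. Nothing available explains these steps. Still open, as far as these compounds go, is whether the low number of compound 1 is specific to methyl, or whether ethyl or an amine on that aromatic carbon would match it.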